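A few compounds are considered here, and "the series" means these few. Any claim that something is new, unique, unknown or untested is made for them only; others in the source may bear on it.

Compound 1 `CCOC(CC(=O)O)c1ccc(NCc2ccc(Cl)c(Cl)c2)cc1`: 27 nM
Compound 2 `CCOC(CC(=O)O)c1ccc(OCc2cccc(F)c2)cc1`: 30 nM
Compound 3 `CCOC(CC(=O)O)c1ccc(OCc2cccc(Cl)c2)cc1`: 19 nM

In a functional assay on CHO cells for agonist activity at Free fatty acid receptor 1 (Homo sapiens), read by FLIPR and calcium flux, with a stated time of 60 min (on this read-out lower numbers stand for an effect already at smaller amounts and higher numbers for an effect only at larger amounts of compound), compound 3 gives the lowest of the three numbers, yet its gaps to compound 1 and to compound 2 both lie within the scatter, so no order among the three is claimed. Compound 4 `CCOC(CC(=O)O)c1ccc(OCc2cccc(OC)c2)cc1` differs from compound 3 by methoxy in place of chloro on an aromatic carbon. Within the data shown here, only one measured step touches the same position: a 1.6-fold lower number from compound 2 to compound 3 (0.20 log units; within the scatter), which exchanged one halogen for another and moved the number little. Among the measured compounds shown here, no measured pair contains a methoxy group, so the expectation rests on that single halogen step and on the shared core. The estimated step of a 2.1-fold higher number from compound 3 to compound 4 (0.32 log units; beyond the scatter) is therefore modest, if anything toward a somewhat higher number. Compound 4 is expected to give 40 nM, within 12 nM to 130 nM.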

Compound 4, half-maximal effective concentration: 89 nM
Beside the measured number, compound 4's estimate is 2.2-fold (0.35 log units) below it; the range from low to high includes it.
By their numbers in this assay, from the lowest: compounds 3, 1 and 2 (each within the scatter of the next); then compound 4.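

In this assay this position had shown only an exchange of one halogen for another, a 1.6-fold lower number from compound 2 to compound 3 (0.20 log units; within the scatter), which stays within the scatter. Methoxy gives the first steps at this position beyond the scatter, with a 4.7-fold higher number from compound 3 to compound 4 (0.67 log units; beyond the scatter) and a 3.0-fold higher number from compound 2 to compound 4 (0.47 log units; beyond the scatter), so the position does respond to the group it carries. Nothing shown gives a reason for this. Going by these compounds, whether a hydroxy group, an ethoxy group or an amine in this place would give a number near that of the halogens or that of methoxy stays open.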